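The source may report more compounds than this note shows. Statements on the series, on what has been measured and on what is new or still open speak of the compounds shown alone.

Values in a physicochemical assay for solubility, in simulated intestinal fluid, measured as kinetic solubility, at pH 6.5; on this read-out lower numbers stand for lower solubility and higher numbers for higher solubility:
- compound 1 `CC(C)c1noc(N2CCC([C@H]3C[C@H]3COCc3ccc(S(C)(=O)=O)cc3F)CC2)n1`: 144000 nM
- compound 2 `CC1(OC(=O)N2CCC([C@H]3C[C@H]3COCc3ccc(-n4cnnn4)cc3F)CC2)CC1`: 127000 nM
- compound 3 `CCOc1cnc(N2CCC([C@H]3C[C@H]3COCc3ccc(S(C)(=O)=O)c(F)c3)CC2)nc1`: 101000 nM

Compound 3, at 101000 nM, lies within the scatter of both other compounds. Compound 4 `CS(=O)(=O)c1ccc(COC[C@@H]2C[C@@H]2C2CCN(c3ncc(F)cn3)CC2)cc1F` is reached from compound 3 by one change, fluoro in place of ethoxy on an aromatic carbon: 5-ethoxypyrimidin-2-yl to 5-fluoropyrimidin-2-yl, fluoro in place of ethoxy on an aromatic carbon. Among the measured compounds shown here, no measured pair differs in one place only, so the size of this change has no direct precedent. All three values sit within the scatter of one another, although the structures differ in more than one place. No shift beyond the scatter is therefore expected, in either direction. The expected step, a 1.1-fold higher number from compound 3 to compound 4 (0.06 log units; within the scatter), is small. For compound 4 the estimated value is 115000 nM, with an expected range of 60000 nM to 200000 nM.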

Compound 4, solubility: 92000 nM
Compound 4: the middle estimate sits 1.3-fold (0.10 log units) above what was measured; the range from low to high includes it.
By their numbers in this assay, from the lowest: compounds 4, 3, 2 and 1 (each within the scatter of the next).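

Within this assay, the change from 5-ethoxypyrimidin-2-yl to 5-fluoropyrimidin-2-yl gives the series its only single-place comparison: a 1.1-fold lower number from compound 3 to compound 4 (0.04 log units; within the scatter). Replacing ethoxy with fluoro at this position, with fewer heavy atoms and one hydrogen-bond acceptor fewer, therefore produces no shift beyond the scatter. Nothing available bears on why.

As far as these compounds go, whether an amine, a carboxylic acid or a longer alkoxy chain at this position would give a step beyond the scatter remains open. So does whether the fluoro-for-ethoxy step would read the same on other ring systems.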